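Moving Chlorines Around the Dichlorophenyl Group

This account rests on a few compounds, and the source may have more. Where it says the series, first, only, none or still open, it means among the compounds named here.

In a functional assay on NCI-H292 cells (Homo sapiens) for inhibition, read by MTT assay, with a stated time of 72 h (on this read-out higher numbers stand for weaker inhibition and lower numbers for stronger inhibition), compound 1 `O=[N+]([O-])c1cccc(-c2csc(N/N=C/c3ccc(C(F)(F)F)cc3)n2)c1` gives 22800 nM, while compound 2 `FC(F)(F)c1ccc(/C=N/Nc2nc(-c3ccc(Cl)cc3Cl)cs2)cc1` gives 10400 nM, the lower of the two numbers. Among the compounds with values here, the one measured step, a 2.2-fold lower number from compound 1 to compound 2 (0.34 log units; beyond the scatter), is modest and swapped 3-nitrophenyl for 2,4-dichlorophenyl, so it bears only loosely on what comes next. Compound 3 `FC(F)(F)c1ccc(/C=N/Nc2nc(-c3ccc(Cl)c(Cl)c3)cs2)cc1` carries 3,4-dichlorophenyl in place of 2,4-dichlorophenyl, the same atoms joined differently: 3,4-dichlorophenyl in place of 2,4-dichlorophenyl on an aromatic carbon. With so little to go on, the expected change is no more than scatter, an estimated 1.0-fold lower number from compound 2 to compound 3 (0.02 log units; within the scatter), with no favoured direction. Compound 3 is expected at 10000 nM, within an estimated range of 4500 nM to 22000 nM.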

Compound 3, half-maximal inhibitory concentration: 6570 nM
Compound 3: middle estimate off by 1.5-fold (0.18 log units), on the high side, and the stated range covers the measured number.
By their numbers in this assay, from the lowest: compounds 3 and 2 (each within the scatter of the next); then compound 1.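

Shifting the chlorines from 2,4-dichlorophenyl to 3,4-dichlorophenyl gives a 1.6-fold lower number from compound 2 to compound 3 (0.20 log units; within the scatter), so this assay does not separate these two arrangements on this aromatic carbon. Compared with 3-nitrophenyl, the new group gives a 3.5-fold lower number from compound 1 to compound 3 (0.54 log units; beyond the scatter), a modest step that matches the earlier one in direction. Nothing available here explains these numbers.

Open, as far as these compounds go, is how the ring would respond to a single chlorine, a methoxy group or an amine in place of these substituents. Also open, from the compounds shown here alone, is how much the trifluoromethyl group at the far end contributes.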